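Trimming the Amide Tail of a Weakly Cytotoxic Series

The source may report more compounds than this note shows. Statements on the series, on what has been measured and on what is new or still open speak of the compounds shown alone.

Compound 1 `C=CC1=C(C(=O)NCc2ccccc2)C(c2ccc(OC)c(OC)c2)OC1` is a weak inhibitor: in a functional assay on SW480 cells (Homo sapiens) for cytotoxicity, read by MTT assay, with a stated time of 24 h (a lower number here means a stronger inhibitor, a higher number a weaker inhibitor), compound 1 gives > 100000 nM, which is a limit of the measurement rather than a number. Compound 2 `C=CC1=C(C(=O)NCc2ccccc2)C(c2ccc(OC)cc2)OC1`, which differs only on the aromatic ring, gives 39500 nM in this assay, so that an at least 2.5-fold lower number from compound 1 to compound 2 (0.40 log units; beyond the scatter). Compound 3 `C=CC1=C(C(=O)NCCCCC)C(c2ccc(F)cc2)OC1` also gives a limit in this assay, namely > 100000 nM. Compound 4 `C=CC1=C(C(=O)NCCC)C(c2ccc(OC)c(OC)c2)OC1` keeps both methoxy groups of compound 1 but carries ethyl in place of phenyl on a saturated chain carbon bound to an amide-type nitrogen. Among the compounds with values here, no measured step touches that position; compound 3, with a plain chain on the amide nitrogen, shows a limit, as does compound 1 (the limit of > 100000 nM in this assay, at which 2 of the 3 values shown sit). Little change is expected, with a number no higher from compound 1 to compound 4 (the limit leaves the size open). Compound 4 is therefore estimated at 100000 nM, between 30000 nM and 300000 nM, most likely again a limit.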

Compound 4, half-maximal inhibitory concentration: > 100000 nM
Compound 4 gave a limit, no number (the forecaster's own chance of this, stated with the estimate: 70%); the middle value lies on the limit itself.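

Compound 1 and compound 4 both end at a limit in this assay rather than at a number, so the step between them cannot be read. The compounds shown leave open whether changing benzyl to propyl alters cytotoxicity at all.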